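The compounds below may be only part of what the source reports. "The series", "measured", "known", "first", "only" and "open" are said of these compounds alone.

Compound 1 `CS(=O)(=O)Oc1c(C(=O)NCc2ccc(F)cc2)nc(Br)c2cccnc12`: "not determined" (no result reported) in a functional assay on MCF7 cells (Homo sapiens) for cytotoxicity, read by MTT assay, with a stated time of 72 h; a higher number here means a weaker inhibitor, a lower number a stronger inhibitor
Compound 2 `CS(=O)(=O)NCCCN(c1nc(C(=O)NCc2ccc(F)cc2)c(O)c2ncccc12)S(C)(=O)=O`: > 20000 nM
Compound 3 `CN(C)c1ccc(CNC(=O)c2nc(Br)c3cccnc3c2N[C@H]2CC[C@H](N)CC2)cc1`: 5000 nM

Three compounds share the core of compound 1, but only two carry a result. In this assay compound 2 reaches only the limit of > 20000 nM, which is a limit and not a number. Compound 3 gives 5000 nM. Compound 1 itself has no reported result, so its standing rests on these two neighbours alone, one of which sits at the limit (the limit of > 20000 nM in this assay, at which 1 of the 3 values shown sits). Compound 4 `Nc1cccc(Nc2c(C(=O)NCc3ccc(F)cc3)nc(Br)c3cccnc23)c1` differs from compound 1 in one place: (3-aminophenyl)amino in place of (methylsulfonyl)oxy on an aromatic carbon. Going by the values given here, no measured pair shows what such a change does here, so no step beyond the scatter can be claimed in either direction. Compound 4 is expected to give about 5000 nM, most likely between 1500 nM and 20000 nM.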

Compound 4, half-maximal inhibitory concentration: 8000 nM
The estimate for compound 4 lay 1.6-fold (0.20 log units) below the measured number; the range from low to high includes it.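

In this assay compound 1 stands as "not determined" (no result reported) while compound 4 gives 8000 nM here, so no step can be read between them. Nothing shown accounts for the value of compound 4. Going by these compounds, what replacing (methylsulfonyl)oxy with (3-aminophenyl)amino does in this assay stays open.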